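A few compounds are considered here, and "the series" means these few. Any claim that something is new, unique, unknown or untested is made for them only; others in the source may bear on it.

Measured compounds in an assay on a subcellular fraction from brain for inhibition of Norepinephrine transporter (Rattus norvegicus); on this read-out higher numbers stand for weaker inhibition and lower numbers for stronger inhibition:
- compound 1, `CN1CC[C@@H](c2ccc(Cl)cc2)[C@H](C(=O)NCc2ccc(CNC(=O)c3cccc(C(F)(F)F)c3)cc2)C1`: 508 nM
- compound 2, `CN1CC[C@@H](c2ccc(Cl)cc2)[C@H](C(=O)NCc2ccc(CNC(=O)c3ccc(Cl)cc3)cc2)C1`: 1540 nM
- compound 3, `CN1CC[C@@H](c2ccc(Cl)cc2)[C@H](C(=O)NCc2ccc(CNC(=O)c3cccc(Cl)c3)cc2)C1`: 1040 nM

Compound 3 gives the second highest number of the three. Its nearest neighbour is compound 2, a 1.5-fold lower number from compound 2 to compound 3 (0.17 log units; within the scatter), and the gap is within the scatter, so no order between compound 2 and compound 3 is claimed. Compound 1 gives the lowest number, a 2.0-fold higher number from compound 1 to compound 3 (0.31 log units; beyond the scatter), and a 3.0-fold higher number from compound 1 to compound 2 (0.48 log units; beyond the scatter); both of these steps are beyond the scatter but modest.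

Compound 4, `CN1CC[C@@H](c2ccc(Cl)cc2)[C@H](C(=O)NCc2ccc(CNC(=O)CCc3ccccc3)cc2)C1`, has not yet been measured in this assay. The change from compound 3 is phenethyl in place of 3-chlorophenyl on a carbonyl carbon. Among the compounds with values here, no measured step exchanges the aromatic ring itself for a phenethyl chain; the measured steps only vary the substituent on that ring or its placement, and all of them stayed within a modest band. Compound 4 is therefore expected to stay in the same band rather than move far: a change of about a 1.4-fold higher number from compound 3 to compound 4 (0.16 log units; within the scatter) is expected, with a higher number somewhat more likely than a lower one, since the ring substituents present in compounds 1, 2 and 3 are all absent in compound 4. Compound 4 is estimated at 1500 nM, within a range of 500 nM to 4500 nM.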

Compound 4, inhibition constant: > 1000 nM
Compound 4: a limit, no number (the forecaster's own chance of this, stated with the estimate: 5%); the middle value lies beyond the limit too.
By their numbers in this assay, from the lowest: compound 1; then compounds 3 and 2 (each within the scatter of the next).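

In this assay compound 4 gives > 1000 nM, which is a limit of the assay and not a number. Exchanging the aromatic ring on the carbonyl carbon for a chain gives an at least 1.9-fold higher number from compound 1 to compound 4 (0.29 log units; that floor lies within the scatter), so phenethyl shows no gain over 3-(trifluoromethyl)phenyl at this position, although that floor does not by itself secure an order between the two compounds. The steps to compound 4 from compound 2 and from compound 3 cannot be read, which leaves the replacement of a chlorophenyl by phenethyl with no size, only a bound set by the assay: the limit of > 1000 nM in this assay, at which 1 of the 4 values shown sits.

From the compounds shown here alone, how far compound 4 lies past its limit remains open, and so does whether the loss of the ring substituent or the insertion of the chain matters more at this position. A benzyl group, a 3-chlorophenethyl group or a 3-(trifluoromethyl)phenethyl group on the same carbonyl carbon would separate those two changes, and a longer chain ending in phenyl would test whether chain length matters.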